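The compounds below may be only part of what the source reports. "The series", "measured", "known", "first", "only" and "open" are said of these compounds alone.

Measured compounds and their values:

Compound 1, `CCOC(=O)c1c(-c2cccc(OC)c2)[nH]c2cc(Cl)c(OC)cc2c1=O`: > 21500 nM
Compound 2, `CCOC(=O)c1c(-c2cccc(Oc3ccccc3)c2)[nH]c2cc(Cl)c(OC)cc2c1=O`: > 21500 nM
Compound 3, `CCOC(=O)c1c(-c2cccc(OC)c2)[nH]c2cc(OC)c(F)cc2c1=O`: > 21500 nM

All three compounds were tested in an ADME assay on HepG2 cells (Homo sapiens) for cytotoxicity, read by luminescence, with a stated time of 72 h; on this read-out lower numbers stand for an effect already at smaller amounts and higher numbers for an effect only at larger amounts of compound. None of the three gave a number. For compound 1 the result > 21500 nM is a limit of the assay. For compound 2 the result > 21500 nM is likewise a limit. For compound 3 the result > 21500 nM is a limit as well. Compound 1 and compound 2 differ in one place, (phenyl in place of methyl on an oxygen on an aromatic ring), and the step that the two limits leave unreadable from compound 1 to compound 2 cannot be read because both values are limits. Compound 3 and compound 1 differ by more than one place, and the difference between the two cores is not broken down here.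

Compound 4, `CCOC(=O)c1c(-c2cccc(Oc3ccccc3)c2)[nH]c2cc(OC)c(F)cc2c1=O`, has not yet been tested. It differs from compound 3 in one place, (phenyl in place of methyl on an oxygen on an aromatic ring), the same change that separates compound 1 from compound 2, made on the core of compound 3. For the step from compound 3 to compound 4 the expectation is that it will stay hidden, a step that the limit leaves unreadable from compound 3 to compound 4, because the limit of > 21500 nM in this assay, at which 3 of the 3 values shown sit, leaves no room to see a change of this kind in either direction. The value of compound 4 in this assay is expected to be about 30000 nM, with a likely range from 12000 nM to 120000 nM, most probably reported as a limit once more.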

Compound 4, half-maximal effective concentration: > 21500 nM
Compound 4: no number, only a limit; the forecaster's own chance of this, stated with the estimate: 85%; the middle value lies beyond the limit too.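

No step can be read from compound 3 to compound 4 in this assay, because neither compound gives a number, only a limit: the limit of > 21500 nM in this assay, at which 4 of the 4 values shown sit.

The compounds shown leave open at what concentration any of them would harm these cells, and whether replacing methoxy with phenoxy changes that concentration on either core.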